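Replacing the aryl group of compound 2 with 3-fluorophenyl

The source may report more compounds than this note shows. Statements on the series, on what has been measured and on what is new or still open speak of the compounds shown alone.

Of the compounds shown here, two built on one shared core have been measured so far. In a functional assay on MV4-11 cells (Homo sapiens) for antiproliferative activity, read by CCK-8 assay, with a stated time of 72 h (on this read-out lower numbers stand for stronger inhibition and higher numbers for weaker inhibition), compound 1 `Cn1cc(-c2cccc(C(C)(C)O)c2)c2cc(C(=O)NCc3ccc(C(=O)Nc4ccccc4N)cc3)[nH]c2c1=O` gives 2200 nM and compound 2 `COc1ccc(C(C)(C)O)cc1-c1cn(C)c(=O)c2[nH]c(C(=O)NCc3ccc(C(=O)Nc4ccccc4N)cc3)cc12` gives 420 nM, which makes compound 2 the lower of the two numbers. Within the data shown here, the only measured step is a 5.2-fold lower number from compound 1 to compound 2 (0.72 log units; beyond the scatter), and it comes with methoxy in place of hydrogen on an aromatic carbon.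

The next compound, compound 3 `Cn1cc(-c2cccc(F)c2)c2cc(C(=O)NCc3ccc(C(=O)Nc4ccccc4N)cc3)[nH]c2c1=O`, has not yet been measured in this assay. It differs from compound 2 as follows: 3-fluorophenyl in place of 5-(1-hydroxy-1-methylethyl)-2-methoxyphenyl on an aromatic carbon. In words, 3-fluorophenyl stands in place of 5-(1-hydroxy-1-methylethyl)-2-methoxyphenyl on an aromatic carbon. The methoxy group is therefore lost, and like compound 3, compound 1 has none, reading 2200 nM. Among the measured compounds shown here, no measured compound carries 3-fluorophenyl, so this single step is a weak guide, and the range must stay wide. For the measured compounds named here, a move back towards a higher number, of about the size of the one measured step, is expected. The expected change is a 3.6-fold higher number from compound 2 to compound 3 (0.55 log units; beyond the scatter). The estimated value for compound 3 is 1500 nM, with an expected range from 500 nM to 4500 nM.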

Compound 3, half-maximal inhibitory concentration: 210 nM
Compound 3: middle estimate off by 7.1-fold (0.85 log units), on the high side; the whole stated range lies above it.
By their numbers in this assay, from the lowest: compounds 3 and 2 (each within the scatter of the next); then compound 1.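

In this assay, this carbon of the shared core takes a far simpler aryl group without a step beyond the scatter (a 2.0-fold lower number from compound 2 to compound 3 (0.30 log units; within the scatter)): 3-fluorophenyl, with fewer heavy atoms and 0 hydrogen-bond donors, reads on a par with 5-(1-hydroxy-1-methylethyl)-2-methoxyphenyl. The exchange of 1-hydroxy-1-methylethyl for fluoro on the aryl ring gives a large step (a 10-fold lower number from compound 1 to compound 3 (1.02 log units; beyond the scatter)), larger than the one seen earlier with methoxy. Methoxy is therefore not required for a low number among these compounds, since compound 3 has none, while compound 1, also without methoxy, goes against any simple link between its absence and a high number. Nothing available here accounts for these differences.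

The compounds shown leave open whether the step from compound 1 rests on fluoro entering or on 1-hydroxy-1-methylethyl leaving, a question that plain phenyl at this carbon would address. Also open, as far as these compounds go, is how a methoxy added to the 3-fluorophenyl ring would read, and how chloro, a nitrile or an amine would read in place of the fluoro.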